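A few compounds are considered here, and "the series" means these few. Any claim that something is new, unique, unknown or untested is made for them only; others in the source may bear on it.

Among the measured compounds shown here, in a functional assay on SK-OV-3 cells (Homo sapiens) for cytotoxicity, read by sulforhodamine B assay (on this read-out lower numbers stand for stronger inhibition and higher numbers for weaker inhibition), three compounds built on a shared core have numbers so far. Compound 1 `COCCNc1nc(-c2ccccc2)nc2ccccc12` gives 22.9 ug/mL, compound 2 `CN1CCCN(c2nc(-c3ccccc3)nc3ccccc23)CC1` gives 26.1 ug/mL, and compound 3 `CC(C)Nc1nc(-c2ccccc2)nc2ccccc12` gives 16.9 ug/mL. Compound 3 therefore stands level with the other two, as its gaps to them lie within the usual scatter of repeat measurements.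

The next structure, compound 4 `c1ccc(-c2nc(NC3CCCCC3)c3ccccc3n2)cc1`, has cyclohexyl in place of isopropyl on a nitrogen on an aromatic ring. For the measured compounds named here, no measured step makes this exact exchange. The closest evidence is isopropyl in place of 2-methoxyethyl on that nitrogen, which gave a 1.4-fold lower number from compound 1 to compound 3 (0.13 log units; within the scatter). Replacing the whole amino group gave a 1.5-fold lower number from compound 2 to compound 3 (0.19 log units; within the scatter) and a 1.1-fold higher number from compound 1 to compound 2 (0.06 log units; within the scatter). As far as these compounds go, all three steps stayed within the scatter, though none of them adds a ring of carbon only, so that change remains untested. No shift beyond the scatter is expected, and the estimated step is a 1.1-fold lower number from compound 3 to compound 4 (0.05 log units; within the scatter). For compound 4 the estimated value is 15 ug/mL, with an expected range from 6.5 ug/mL to 32 ug/mL.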

Compound 4, half-maximal inhibitory concentration: 9.82 ug/mL
Compound 4: middle estimate off by 1.5-fold (0.18 log units), on the high side; the range from low to high includes it.
By their numbers in this assay, from the lowest: compounds 4, 3, 1 and 2 (each within the scatter of the next, the first and the last beyond it).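

In this assay, this nitrogen on an aromatic ring can carry a six-membered ring of carbon only, and cyclohexyl stands level with isopropyl (a 1.7-fold lower number from compound 3 to compound 4 (0.24 log units; within the scatter)). Compound 4 also opens the first gaps in the series that clear the usual scatter, though both are modest: one against the 4-methyl-1,4-diazepan-1-yl group (a 2.7-fold lower number from compound 2 to compound 4 (0.42 log units; beyond the scatter)) and one against the 2-methoxyethyl group (a 2.3-fold lower number from compound 1 to compound 4 (0.37 log units; beyond the scatter)). No measurement shown gives a reason for these gaps.

As far as these compounds go, whether the ring size matters remains open, since a cyclopentyl or cycloheptyl group on this nitrogen would be needed to test it. It is also unclear how a cyclohexyl ring carrying a hydroxyl group, or a flat phenyl ring in its place, would compare with compound 4.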